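A second methoxy on compound 2

The source may report more compounds than this note shows. Statements on the series, on what has been measured and on what is new or still open speak of the compounds shown alone.

compound 1 `C=C(Br)C(=O)Nc1ccc(C(=O)/C=C/c2ccc(OC)cc2)cc1`: 1000 nM
compound 2 `C=C(Br)C(=O)Nc1ccc(C(=O)/C=C/c2ccccc2OC)cc1`: 370 nM
compound 3 `C=C(Br)C(=O)Nc1ccc(C(=O)/C=C/c2cccc(OC)c2OC)cc1`: 550 nM

In a functional assay on FM3A cells (Mus musculus) for antiproliferative activity, with a stated time of 48 h (on this read-out lower numbers stand for stronger inhibition and higher numbers for weaker inhibition), compound 2 gives 370 nM and shares the low end of this small series with compound 3, the two lying within the scatter of each other. Compound 1 sits clearly higher, as a 2.7-fold lower number from compound 1 to compound 2 (0.43 log units; beyond the scatter) shows.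

The next compound, compound 4 `C=C(Br)C(=O)Nc1ccc(C(=O)/C=C/c2ccc(OC)cc2OC)cc1`, differs from compound 2 in one place: methoxy in place of hydrogen on an aromatic carbon. This is methoxy in place of hydrogen on an aromatic carbon.

Among the measured compounds shown here, two measured steps bear on it. The closest in kind is a 1.5-fold higher number from compound 2 to compound 3 (0.17 log units; within the scatter), which is also methoxy in place of hydrogen on an aromatic carbon and does not leave the scatter. The other is a 2.7-fold lower number from compound 1 to compound 2 (0.43 log units; beyond the scatter), where 2-methoxyphenyl stands in place of 4-methoxyphenyl. The methoxy entering compound 4 stands para to a large group, as it does in the 4-methoxyphenyl of compound 1, so some movement towards higher numbers is possible.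

On these two steps, a small rise that stays about within the scatter is expected in this assay. The expected step is a 1.4-fold higher number from compound 2 to compound 4 (0.13 log units; within the scatter). Compound 4 is estimated at 500 nM, with an expected range of 230 nM to 1050 nM.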

Compound 4, half-maximal inhibitory concentration: 1200 nM
The estimate for compound 4 lay 2.4-fold (0.38 log units) below the measured number; measured number outside the range, above it.
By their numbers in this assay, from the lowest: compounds 2, 3, 1 and 4 (each within the scatter of the next, the first and the last beyond it).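

In this assay, placing a second methoxy on compound 2 changes the read-out beyond the scatter when the new group stands para to a large group and meta to a methoxy group: the result is a 3.2-fold higher number from compound 2 to compound 4 (0.51 log units; beyond the scatter). The earlier addition of methoxy to compound 2 had not shown that this change could leave the scatter, so the outcome of adding this group to compound 2 depends on the carbon that receives it. Read from the other side, methoxy in place of hydrogen gives a 1.2-fold higher number from compound 1 to compound 4 (0.08 log units; within the scatter), and the same change thus gives closely matching steps on two cores, although on compound 2 it was made at a different carbon in the step that leaves the scatter: the same change on two cores in this assay, a 1.5-fold higher number (0.17 log units; within the scatter) from compound 2 to compound 3 and a 1.2-fold higher number (0.08 log units; within the scatter) from compound 1 to compound 4, 1.2-fold (0.09 log units) apart, within the scatter of two such steps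

The compounds shown leave open whether the rise at this carbon belongs to methoxy itself or would also follow from another group, such as a hydroxy group, a methyl group or a chlorine atom, in place of hydrogen on compound 2. They also leave open whether an ethoxy group at this carbon would move the number further, and whether the step holds in any other cell line.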